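Amino to methylamino, starting from a limit

A few compounds are considered here, and "the series" means these few. Any claim that something is new, unique, unknown or untested is made for them only; others in the source may bear on it.

Going by the values given here, in a functional assay on A2780 cells (Homo sapiens) for antiproliferative activity, read by MTT assay, with a stated time of 72 h (a lower number here means a stronger inhibitor of growth, a higher number a weaker inhibitor of growth), compound 1 (`COc1cc(OC)c(/C=C/S(=O)(=O)Cc2cnc(Cl)cn2)c(OC)c1`) gives 4760 nM, the only true number in this small set. Compound 2 (`COc1cc(OC)c(/C=C/S(=O)(=O)Cc2nc(Cl)ncc2OC)c(OC)c1`) reaches only a limit, > 10000 nM. As far as these compounds go, compound 3 (`COc1cc(OC)c(/C=C/S(=O)(=O)Cc2nc(N)ncc2OC)c(OC)c1`) also reaches only a limit, > 10000 nM, so its real position is unknown. Compound 4 (`CNc1ncc(OC)c(CS(=O)(=O)/C=C/c2c(OC)cc(OC)cc2OC)n1`) differs from it by methyl in place of hydrogen on a nitrogen on an aromatic ring, turning amino to methylamino. Two measured steps, an at least 2.1-fold higher number from compound 1 to compound 2 (0.32 log units; beyond the scatter) and an at least 2.1-fold higher number from compound 1 to compound 3 (0.32 log units; beyond the scatter), replace the whole group on the saturated chain carbon, so they say little about this small change. The closest step, a step that the two limits leave unreadable from compound 2 to compound 3, changes the same ring carbon substituent, but its size cannot be read. Among the compounds with values here, no measured step therefore points to a gain or a loss in this assay, and no shift beyond the scatter is expected. The expected outcome is a step that the limit leaves unreadable from compound 3 to compound 4, and a further limit is the most likely report. The estimated value for compound 4 is 12000 nM, with an expected range of 5000 nM to 30000 nM.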

Compound 4, concentration for 50% growth inhibition: 7540 nM
For compound 4 the middle estimate is 1.6-fold (0.20 log units) above the measured one; low and high end bracket the measured number.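

In this assay compound 4 gives 7540 nM, so with methylamino on this ring carbon the series yields a true number, which neither the amino nor the chloro compound provides. Methyl in place of hydrogen on the nitrogen gives an at least 1.3-fold lower number from compound 3 to compound 4 (0.12 log units; that floor lies within the scatter), and methylamino in place of chloro gives an at least 1.3-fold lower number from compound 2 to compound 4 (0.12 log units; that floor lies within the scatter), but each is only a floor that lies within the scatter, with the true size possibly larger. Both steps start from a value that is a limit and not a number: the limit of > 10000 nM in this assay, at which 2 of the 4 values shown sit.

As far as these compounds go, whether an ethylamino or a dimethylamino group at this place would move the number in either direction remains open. From the compounds shown here alone, the real distance of compound 3 from compound 4 also stays unknown, and the step between the two limit compounds cannot be read.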